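Smaller Ring on the Thiocarbonyl Carbon

The compounds below may be only part of what the source reports. "The series", "measured", "known", "first", "only" and "open" are said of these compounds alone.

Of the compounds shown here, two built on one shared core have been tested in a functional assay on A-375 cells (Homo sapiens) for antiproliferative activity, read by CCK-8 assay, with a stated time of 72 h, tested at 2 uM; on this read-out lower numbers stand for a weaker effect and higher numbers for a stronger effect at the one concentration tested. Compound 1, `Nc1ccccc1NC(=O)c1ccc(CSC(=S)N2CCN(Cc3ccccn3)CC2)cc1`, gives 20.7%. Compound 2, `Nc1ccccc1NC(=O)c1ccc(CSC(=S)N2CCCc3ccccc32)cc1`, gives 26.5%. Compound 2 holds the higher of these two numbers, but its gap to compound 1 lies within the usual scatter, so the two cannot be told apart on this evidence. Compound 3, `CC1CCCCN1C(=S)SCc1ccc(C(=O)Nc2ccccc2N)cc1`, has not yet been measured. It differs from compound 2 in one place: 2-methylpiperidin-1-yl in place of 1,2,3,4-tetrahydroquinolin-1-yl on a thiocarbonyl carbon. The group that enters keeps a six-membered non-aromatic ring with one hetero atom, while the six-membered aromatic ring of carbon only is lost. For the measured compounds named here, with no step between measured compounds available, the expected step in this assay is a number 4.5 percentage points lower from compound 2 to compound 3 (within the scatter), a small shift, if any, that is not expected to go beyond the scatter. Compound 3 is estimated at 22%, with a range from 8% to 38%.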

Compound 3, a percentage reported as inhibition, at one concentration (the size of the read-out at that concentration, not a potency): 42.5%
Compound 3: middle estimate off by 20.5 percentage points, on the low side; the whole stated range lies below it.
By their numbers in this assay, from the lowest: compounds 1 and 2 (each within the scatter of the next); then compound 3.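

In this assay, for the compounds shown here, 2-methylpiperidin-1-yl in place of 1,2,3,4-tetrahydroquinolin-1-yl on a thiocarbonyl carbon gives a number 16 percentage points higher from compound 2 to compound 3 (beyond the scatter), the first step at this position, and it shows that the group held there can shift this read-out beyond the scatter. The six-membered non-aromatic ring with one hetero atom stays through the change, while the six-membered aromatic ring of carbon only leaves and a methyl group enters, so this one step joins two structural differences. Nothing available here explains the shift.

The compounds shown leave open whether the methyl group or the loss of the aromatic ring carries the step. They also leave open how a plain piperidin-1-yl, a morpholin-4-yl or an open-chain diethylamino group on the thiocarbonyl carbon would read in this assay.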